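Carbonyl-bearing analogues on the anilino-substituted bicyclic core

The source may report more compounds than this note shows. Statements on the series, on what has been measured and on what is new or still open speak of the compounds shown alone.

Measured compounds:
compound 1 `Cc1cccc(Nc2ncnc3oc(C)c(CO)c23)c1` gives 17000 nM in a functional assay on MCF7 cells (Homo sapiens) for cytotoxicity, read by MTT assay, with a stated time of 72 h; a higher number here means a weaker inhibitor, a lower number a stronger inhibitor;
compound 2 `CCCNC(=O)c1c(C)oc2ncnc(Nc3cccc(C)c3)c12` gives > 1000000 nM in this assay, a limit of that assay rather than a number.

Compound 2 thus stands at the limit of > 1000000 nM in this assay, at which 1 of the 2 values shown sits, of this assay, the weaker of the two values shown. The step from it to compound 3 `Cc1cccc(Nc2ncnc3oc(C)c(C(=O)O)c23)c1` is hydroxy in place of propylamino on a carbonyl carbon. Among the compounds with values here, the only measured step, an at least 58-fold higher number from compound 1 to compound 2 (1.76 log units; beyond the scatter), concerns the same carbon but a different exchange, so it informs the size of this step only weakly. It shows that the carbonyl-bearing group moved the value past the limit, and nothing recorded shows that trimming its propylamino part to a hydroxy returns the compound toward the value of compound 1. In this assay compound 3 is therefore expected to remain weak, with a step of an at least 1.6-fold lower number from compound 2 to compound 3 (0.22 log units; that floor lies within the scatter) that may well leave it at the limit again. The estimate for compound 3 is 600000 nM, in the range 50000 nM to 3000000 nM.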

Compound 3, half-maximal inhibitory concentration: 57500 nM
Estimate against measurement, compound 3: 10-fold (1.02 log units) above; the measured number falls inside the stated range.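

In this assay, a carbonyl on this aromatic carbon does not alone account for the poor result of the propylcarbamoyl group: hydroxy in place of propylamino on the carbonyl carbon gives an at least 17-fold lower number from compound 2 to compound 3 (1.24 log units; beyond the scatter). The carboxy group still falls short of hydroxymethyl, with a 3.4-fold higher number from compound 1 to compound 3 (0.53 log units; beyond the scatter), a modest step but beyond the scatter, so hydroxymethyl gives the lowest number of the three groups at this carbon. Compound 2 gives a limit and not a number: the limit of > 1000000 nM in this assay, at which 1 of the 3 values shown sits.

Still open, going by these compounds, is whether the propyl chain or the amide nitrogen itself drives the weak result of compound 2, which a primary carboxamide or an ethylcarbamoyl group at this carbon would help separate. A methyl ester would show whether the free hydroxy of the carboxy group matters to the value of compound 3.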